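This account rests on a few compounds, and the source may have more. Where it says the series, first, only, none or still open, it means among the compounds named here.

In an ADME assay on the whole organism (Rattus norvegicus, strain Sprague-Dawley) for pharmacokinetics, read by LC-MS, at a dose of 5 mg/kg by the oral route (on this read-out lower numbers stand for lower oral bioavailability and higher numbers for higher oral bioavailability), compound 1 `Cc1cccc(Cl)c1CN1CCc2cc(-c3c(C)nc(C)c([C@H](OC(C)(C)C)C(=O)O)c3N3CCC(C)(C)CC3)ccc2C1` gives 35%, compound 2 `Cc1cccc(F)c1CN1CCc2cc(-c3c(C)nc(C)c([C@H](OC(C)(C)C)C(=O)O)c3N3CCC(C)(C)CC3)ccc2C1` gives 70% and compound 3 `Cc1nc(C)c([C@H](OC(C)(C)C)C(=O)O)c(N2CCC(C)(C)CC2)c1-c1ccc2c(c1)CCN(c1nccc(-c3cnccn3)n1)C2` gives 38%. Compound 3 thus stands level with compound 1 and well short of compound 2. Compound 4 `Cc1nc(C)c([C@H](OC(C)(C)C)C(=O)O)c(N2CCC(C)(C)CC2)c1-c1ccc2c(c1)CCN(c1nc3cnccc3s1)C2` differs from compound 3 by a group of 9 heavy atoms (6 carbon, 2 nitrogen, 1 sulfur; one five-membered aromatic ring with 2 hetero atoms, one six-membered aromatic ring with 1 hetero atom) in place of a group of 12 heavy atoms (8 carbon, 4 nitrogen; 2 six-membered aromatic rings with 2 hetero atoms each), on an amine nitrogen in a ring. Two measured steps changed the group at that place, a number 3 percentage points higher from compound 1 to compound 3 (within the scatter) and a number 32 percentage points lower from compound 2 to compound 3 (beyond the scatter); they differ in size, neither tests the entering group, and so no step beyond the scatter is expected in this assay. The remaining step, a number 35 percentage points higher from compound 1 to compound 2 (beyond the scatter), does not touch that place. Compound 4 is estimated at 40%, with an expected range of 20% to 65%. The expected step is a number 2 percentage points higher from compound 3 to compound 4 (within the scatter).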

Compound 4, oral bioavailability: > 100%
Compound 4: a limit, no number; the forecaster's own chance of this, stated with the estimate: 0%; at least 60 percentage points between middle value and limit.
By their numbers in this assay, from the lowest: compounds 1 and 3 (each within the scatter of the next); then compound 2. At a limit, above all of these: compound 4.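

For the compounds shown here, at the amine nitrogen in a ring, the entering group with one five-membered and one six-membered aromatic ring changes the read-out in this assay by far more than the earlier compounds foreshadowed: a number at least 62 percentage points higher from compound 3 to compound 4 (beyond the scatter), a number at least 30 percentage points higher from compound 2 to compound 4 (beyond the scatter) and a number at least 65 percentage points higher from compound 1 to compound 4 (beyond the scatter). Going by these compounds alone, this place can therefore shift the read-out past even the best earlier group, the one in compound 2. The value of compound 4 is a limit of the assay, not a number: the limit of > 100% in this assay, at which 1 of the 4 values shown sits.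

From the compounds shown here alone, the true size of these steps stays open. So does whether an oxygen in place of the sulfur of the entering group would keep them.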